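The source may hold more compounds than are shown below. What is called first, only, known or untested is meant among the compounds shown, and "the series" means these compounds.

Three compounds of this series have been run in a functional assay on U-937 cells (Homo sapiens) for cytotoxicity, read by MTT assay, with a stated time of 48 h; on this read-out lower numbers stand for stronger inhibition and higher numbers for weaker inhibition. Compound 1 `Fc1ccc2nc(-c3ccccc3)nc(Nc3ccccc3)c2c1` reaches only the limit of the assay, reported as > 50000 nM (the limit of > 50000 nM in this assay, at which 1 of the 3 values shown sits). Compound 2 `Fc1cccc(-c2nc(Nc3ccccc3)c3cc(F)ccc3n2)c1` gives 45500 nM in this assay. Compound 3 `COc1ccc(Nc2nc(-c3cccc(F)c3)nc3ccc(F)cc23)cc1` gives 41100 nM, the lower of the two recorded numbers, though its gap to compound 2 lies within the scatter. Both measured steps are small: an at least 1.0-fold lower number from compound 1 to compound 2 (0.04 log units; that floor lies within the scatter) and a 1.1-fold lower number from compound 2 to compound 3 (0.04 log units; within the scatter) each stay within the scatter.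

Compound 4 `Fc1cccc(-c2nc(Nc3ccc(Cl)cc3)c3cc(F)ccc3n2)c1` has not yet been measured. It differs from compound 3 by chloro in place of methoxy on an aromatic carbon. Among the compounds with values here, no measured step exchanges methoxy for chloro. The nearest guide is the step from compound 2 to compound 3, which adds methoxy at that same carbon and shows no effect beyond the scatter, so taking the methoxy away again is not expected to move the number either. For the arrival of chloro on that ring there is no measured comparison at all. In this assay a step of a 1.0-fold lower number from compound 3 to compound 4 (0.01 log units; within the scatter) is therefore expected, which amounts to none beyond the scatter. Compound 4 is estimated at 40000 nM, with a range from 12000 nM to 60000 nM, and a fair chance that the assay returns only a limit.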

Compound 4, half-maximal inhibitory concentration: 32700 nM
For compound 4 the middle estimate is 1.2-fold (0.09 log units) above the measured one, and the stated range covers the measured number.
By their numbers in this assay, from the lowest: compounds 4, 3 and 2 (each within the scatter of the next). At a limit, above all of these: compound 1.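

Within the data shown here, the result gives the first measured exchange of one substituent for another at this carbon, para to a large group: going from 4-methoxyphenyl to 4-chlorophenyl in this assay brings a 1.3-fold lower number from compound 3 to compound 4 (0.10 log units; within the scatter), and chloro in place of hydrogen at the same carbon brings a 1.4-fold lower number from compound 2 to compound 4 (0.14 log units; within the scatter). Hydrogen, methoxy and chloro have now all been read at this one position, and none of the three separates from the others beyond the scatter, even though methoxy carries a hydrogen-bond acceptor and chloro carries none. The change therefore does not lift this part of the series out of the range it already occupied, and compound 1 remains a limit and not a number: the limit of > 50000 nM in this assay, at which 1 of the 4 values shown sits.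

The compounds shown leave open whether any other group at this carbon, such as an amine, a carboxylic acid or a longer chain like butoxy, would move the number beyond the scatter. They also leave open why these steps stay so small, and whether a change elsewhere on the shared core would matter more than one at this position.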